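The source may report more compounds than this note shows. Statements on the series, on what has been measured and on what is new or still open speak of the compounds shown alone.

Measured compounds in the series:
- compound 1, `CCCCCCCCCCCC(=O)OC[C@H](CSC[C@@H](N)C(=O)NCCOCCOS(=O)(=O)O)OC(=O)CCCCCCCCCCC`; in an assay on HEK293 cells for agonist activity at Toll-like receptor 2 (Homo sapiens) (a lower number here means that less compound is needed, a higher number that more compound is needed for the effect), compound 1 gives 61 nM
- compound 2, `CCCCCCCCCCCC(=O)OC[C@H](CSC[C@@H](N)C(=O)NC(C)CCc1ccccc1)OC(=O)CCCCCCCCCCC`; compound 2 gives 160 nM
- compound 3, `CCCCCCCCCCCC(=O)OC[C@H](CSC[C@@H](N)C(=O)N[C@@H](CC)COCC(=O)O)OC(=O)CCCCCCCCCCC`; compound 3 gives 6500 nM

Compound 3 stands at the highest number of the three: the step of a 110-fold higher number from compound 1 to compound 3 (2.03 log units; beyond the scatter) and the step of a 41-fold higher number from compound 2 to compound 3 (1.61 log units; beyond the scatter) are both beyond the scatter, so compound 3 needs clearly more material than either of the others. The two lower numbers sit closer together, the step of a 2.6-fold higher number from compound 1 to compound 2 (0.42 log units; beyond the scatter) being only modest.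

The next compound is compound 4, `CCCCCCCCCCCC(=O)OC[C@H](CSC[C@@H](N)C(=O)NCCCN)OC(=O)CCCCCCCCCCC`. Relative to compound 3 the change is 3-aminopropyl in place of 1-((carboxymethoxy)methyl)propyl on an amide-type nitrogen. Going by the values given here, no measured step moves from this particular group to a 3-aminopropyl group, so the change is read only indirectly. Among the compounds with values here, the two steps that bear on it are the ones leading into compound 3: both replacements of the amide substituent that end at the 1-((carboxymethoxy)methyl)propyl group cost a large amount, and a replacement that removes it again is therefore expected to run the other way, toward the numbers of compound 1 and compound 2, though the new group has no measured precedent of its own.

For compound 4 a step of a 26-fold lower number from compound 3 to compound 4 (1.41 log units; beyond the scatter) is expected, giving an estimated 250 nM with a range from 40 nM to 2500 nM.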

Compound 4, half-maximal effective concentration: 1960 nM
Estimate against measurement, compound 4: 7.8-fold (0.89 log units) below, within the range that was stated.
By their numbers in this assay, from the lowest: compound 1; then compound 2; then compound 4; then compound 3.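

Notes on the amide substituent: in this assay, exchanging the 1-((carboxymethoxy)methyl)propyl group for 3-aminopropyl gives only a modest gain, a 3.3-fold lower number from compound 3 to compound 4 (0.52 log units; beyond the scatter), so losing that group does not by itself restore the low numbers of the series. The 3-aminopropyl group still stands well off both better compounds, with a 12-fold higher number from compound 2 to compound 4 (1.09 log units; beyond the scatter) and a 32-fold higher number from compound 1 to compound 4 (1.51 log units; beyond the scatter), which makes it a poor replacement in its own right and shows that this position separates substituents over a wide span, with compound 3 and compound 4 both clearly on the high side. No measurement available here accounts for the gap between compound 4 and the two lower compounds.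

Open, going by these compounds, is whether the terminal amine or the short propyl chain sets the number of compound 4, which a 3-hydroxypropyl group or a longer chain such as 6-aminohexyl would help to separate. Also open, on these data alone, is whether the sulfate ester of compound 1 matters as such, a question that a carboxylic acid on the same 2-(2-ethoxy)ethyl chain would address.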